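A few compounds are considered here, and "the series" means these few. Any claim that something is new, unique, unknown or untested is made for them only; others in the source may bear on it.

Three compounds have been measured in an assay on CHO cells for displacement of a labelled ligand from adenosine receptor A1 (Homo sapiens), read by scintillation counting, with a stated time of 120 min, tested at 10 uM; a higher number here means more inhibition at the concentration tested (going by the name of the read-out), a lower number less inhibition:

compound 1, `Nc1scc(CN2CCN(c3ccc([N+](=O)[O-])cc3)CC2)c1C(=O)c1ccc(Cl)cc1`: 1%
compound 2, `Nc1scc(CN2CCN(C3CCCCCC3)CC2)c1C(=O)c1ccc(Cl)cc1`: 0%
compound 3, `Nc1scc(CN2CCN(c3ccccc3F)CC2)c1C(=O)c1ccc(Cl)cc1`: 4%

All three share one core and differ only in the group on the amine nitrogen of the six-membered ring. Compound 1 sits within the scatter of both of the others: the step of a number 1 percentage points lower from compound 1 to compound 2 (within the scatter) and the step of a number 3 percentage points higher from compound 1 to compound 3 (within the scatter) are each too small to read as a change, as is the step of a number 4 percentage points higher from compound 2 to compound 3 (within the scatter). None of the three shows any appreciable inhibition in this assay.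

Compound 4, `Nc1scc(CN2CCN(c3cc(F)cc(F)c3)CC2)c1C(=O)c1ccc(Cl)cc1`, is not yet measured. It differs from compound 1 in one place: 3,5-difluorophenyl in place of 4-nitrophenyl on an amine nitrogen in a ring. The closest guide is the step from compound 1 to compound 3, where one aryl group was exchanged for another fluorine-bearing aryl group and the number stayed within the scatter; the exchanges to compound 2 and between compound 2 and compound 3 were likewise flat. Compound 4 is therefore expected to give 2%, with a likely range from -6% to 10%. The expected step is a number 1 percentage points higher from compound 1 to compound 4 (within the scatter), that is, nothing beyond the scatter.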

Compound 4, a percentage reported as inhibition, at one concentration (the size of the read-out at that concentration, not a potency): 0%
Compound 4: the middle estimate sits 2 percentage points above what was measured; measured number inside the range.
By their numbers in this assay, from the lowest: compounds 2, 4, 1 and 3 (each within the scatter of the next).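

In this assay, the 3,5-difluorophenyl group on the amine nitrogen in the ring leaves the picture flat, with a number 1 percentage points lower from compound 1 to compound 4 (within the scatter), a number 4 percentage points lower from compound 3 to compound 4 (within the scatter) and no change at the digits printed from compound 2 to compound 4 (within the scatter). The hydrogen-bond acceptors counted on the 4-nitrophenyl group are absent from the 3,5-difluorophenyl group, yet no step beyond the scatter follows, and none of the four groups on this nitrogen gives appreciable inhibition. No measured evidence is available that bears on this result.

The compounds shown leave open whether a benzyl group, a longer alkyl chain or a carboxylic acid on this nitrogen would move the number beyond the scatter. They also leave open whether any change to the shared core itself would do so, since all four compounds carry it unchanged.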